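The compounds below may be only part of what the source reports. "The series", "measured", "known", "first", "only" and "open" are said of these compounds alone.

Of the compounds shown here, two with a shared core have been measured in an assay on HEK293 cells for binding affinity to Urotensin-2 receptor (Homo sapiens), read by radioligand binding; on this read-out higher numbers stand for weaker inhibition and lower numbers for stronger inhibition. Compound 1 `CN(C)CCCOc1ccc(CN2CC[C@H](NC(=O)c3cc(Cl)cc(Cl)c3)C2)cc1` carries a 3,5-dichlorophenyl on the carbonyl carbon of its amide; in this assay compound 1 gives 2000 nM. Compound 2 `Cc1cc(C(=O)N[C@H]2CCN(Cc3ccc(OCCCN(C)C)cc3)C2)ccc1Br` carries a 4-bromo-3-methylphenyl at the same place; in this assay compound 2 gives 631 nM. Among the measured compounds shown here, the only measured step is a 3.2-fold lower number from compound 1 to compound 2 (0.50 log units; beyond the scatter), which puts compound 2 at the lowest of the two numbers, with compound 1 as its nearest neighbour.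

Compound 3 `CN(C)CCCOc1ccc(CN2CC[C@H](NC(=O)c3ccccc3)C2)cc1` has not yet been measured. It differs from compound 2 in one place: phenyl in place of 4-bromo-3-methylphenyl on a carbonyl carbon. Both halogens and the methyl group are thus gone, leaving a bare phenyl. For the measured compounds named here, the measured step from compound 1 to compound 2 shows that exchanging one substituted phenyl for another shifts the number by a modest amount, but no measured pair shows what removing all substituents does. With the two substituted variants both giving stronger binding than what an unsubstituted phenyl is expected to give, compound 3 is estimated to be weaker than compound 2, the step being a 4.8-fold higher number from compound 2 to compound 3 (0.68 log units; beyond the scatter). Compound 3 is therefore expected to give about 3000 nM, within a range from 1000 nM to 10000 nM.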

Compound 3, inhibition constant: 2510 nM
The estimate for compound 3 lay 1.2-fold (0.08 log units) above the measured number; the range from low to high includes it.
By their numbers in this assay, from the lowest: compound 2; then compounds 1 and 3 (each within the scatter of the next).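

In this assay, among the compounds shown here, the bare phenyl shows for the first time what this place on the carbonyl carbon gives with no substituents on the ring: a 4.0-fold higher number from compound 2 to compound 3 (0.60 log units; beyond the scatter), so losing the bromine and the methyl group together weakens binding by more than the scatter. The dichloro compound behaves differently, with a 1.3-fold higher number from compound 1 to compound 3 (0.10 log units; within the scatter), so the 3,5-dichlorophenyl and the phenyl cannot be told apart in this assay. Substitution on this ring therefore does not strengthen binding as such: of the two substituted rings, only the 4-bromo-3-methylphenyl of compound 2 stands clearly apart from the phenyl, and compound 1 goes against any general rule that substituents help.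

There is no evidence here to explain why these two substituted rings differ. The compounds shown leave open whether the bromine or the methyl group carries the step, which a 4-bromophenyl or a 3-methylphenyl group would separate, and how an amine or a carboxylic acid on the same ring would read.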